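Methyl ether of compound 2: expectation on thin evidence

The source may report more compounds than this note shows. Statements on the series, on what has been measured and on what is new or still open speak of the compounds shown alone.

Compound 2 has the structure `O=c1[nH]c(=O)n([C@H]2C[C@H](O)[C@@H](CO)O2)cc1C#CCO`. In a functional assay on L1210 cells (Mus musculus) (a lower number here means a stronger inhibitor, a higher number a weaker inhibitor), compound 2 reaches only the limit of the assay, > 1000 ug/mL, and no number. Its companion compound 1, with the structure `O=c1[nH]c(=O)n([C@H]2C[C@H](O)[C@@H](CO)O2)cc1C#CCCO`, carries hydroxymethyl where compound 2 carries hydroxy on the saturated chain carbon bound to the triple-bonded carbon. In this assay compound 1 likewise gives only a limit, > 1000 ug/mL. The step that the two limits leave unreadable from compound 1 to compound 2 therefore cannot be sized, which is what the limit of > 1000 ug/mL in this assay, at which 2 of the 2 values shown sit, records. Compound 3, with the structure `COCC#Cc1cn([C@H]2C[C@H](O)[C@@H](CO)O2)c(=O)[nH]c1=O`, differs from compound 2 by methyl in place of hydrogen on an oxygen on a saturated carbon. Among the measured compounds shown here, no measured step bears on this change: the single step between the two measured compounds is unreadable, and both values sit at the limit, so the data give no direction and no size for a methyl on the oxygen. Compound 3 is therefore expected to stand where compound 2 stands, with a number no higher from compound 2 to compound 3 (the limit leaves the size open) as the expected step. The estimate for compound 3 in this assay is 1000 ug/mL, within 300 ug/mL to 3000 ug/mL, and the assay is expected most likely to report only a limit again.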

Compound 3, concentration for 50% inhibition: 254 ug/mL
For compound 3 the middle estimate is 3.9-fold (0.60 log units) above the measured one, outside the stated range (below it).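

In this assay, among the compounds shown here, replacing 3-hydroxyprop-1-yn-1-yl with 3-methoxyprop-1-yn-1-yl gives the only readable number in the set, with an at least 3.9-fold lower number from compound 2 to compound 3 (0.59 log units; beyond the scatter). The change from hydroxymethyl to methoxy on the saturated chain carbon bound to a triple-bonded carbon points the same way, with an at least 3.9-fold lower number from compound 1 to compound 3 (0.59 log units; beyond the scatter). For the compounds shown here, this shows that the chain end does affect the result in this assay, which the earlier pair could not show, and that a methyl on the oxygen is the one change here that leads to a number rather than a limit: the limit of > 1000 ug/mL in this assay, at which 2 of the 3 values shown sit.

From the compounds shown here alone, the true size of both steps remains open, since each starts from a limit, and so does the question of whether the gain comes from the added methyl or from the loss of the hydroxy hydrogen. It is also unknown how an ethyl ether, a longer chain carrying a methoxy end, or an amine in the place of the methoxy would stand in this assay.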